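This account rests on a few compounds, and the source may have more. Where it says the series, first, only, none or still open, it means among the compounds named here.

Measured so far in a functional assay on SiHa cells (Homo sapiens) for inhibition, read by sulforhodamine B assay; on this read-out higher numbers stand for weaker inhibition of growth and lower numbers for stronger inhibition of growth:
compound 1 `COc1ccc(-c2ccc(-c3ccc(-c4nc5ccccc5[nH]4)cc3)cc2)cc1`: 2760 nM
compound 2 `Oc1cccc2[nH]c(-c3ccc(-c4ccc(-c5ccc(OC(F)(F)F)cc5)cc4)cc3)nc12`: 8410 nM
compound 3 `Oc1ccc(-c2ccc(-c3ccc(-c4nc5c(O)cccc5[nH]4)cc3)cc2)cc1`: 2410 nM

Compound 3 and compound 1 share the low end of these numbers, within the usual scatter of each other, while compound 2 stands clearly higher. Compound 4 `COc1ccc(-c2ccc(-c3ccc(-c4nc5c(O)cccc5[nH]4)cc3)cc2)cc1` differs from compound 3 in one place: methyl in place of hydrogen on an oxygen on an aromatic ring. This is methyl in place of hydrogen on an oxygen on an aromatic ring, which turns 4-hydroxyphenyl into 4-methoxyphenyl.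

Going by the values given here, one measured step concerns the same oxygen: a 3.5-fold lower number from compound 2 to compound 3 (0.54 log units; beyond the scatter). That modest step swaps trifluoromethyl for hydrogen, so read backwards it suggests that capping the oxygen may raise the number. Methyl is a different group from trifluoromethyl, however, so this is only a rough guide. Compound 1 also carries 4-methoxyphenyl and gives 2760 nM, but it differs from compound 4 elsewhere on the core, so it offers only indirect support for a small change.

In this assay, a small upward shift is therefore expected, and it may well stay within the scatter. The estimated step is a 1.4-fold higher number from compound 3 to compound 4 (0.14 log units; within the scatter). For compound 4 the estimated value is 3300 nM, with an expected range of 1500 nM to 7500 nM.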

Compound 4, concentration for 50% growth inhibition: 4800 nM
Compound 4: the middle estimate sits 1.5-fold (0.16 log units) below what was measured; the range from low to high includes it.
By their numbers in this assay, from the lowest: compounds 3, 1, 4 and 2 (each within the scatter of the next, the first and the last beyond it).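

In this assay, the direct swap of hydrogen for methyl on this oxygen, which turns 4-hydroxyphenyl into 4-methoxyphenyl, gives a step that remains within the scatter (a 2.0-fold higher number from compound 3 to compound 4 (0.30 log units; within the scatter)), so no effect of this change can be claimed from these two compounds. Methyl in place of trifluoromethyl on the same oxygen also remains within the scatter (a 1.8-fold lower number from compound 2 to compound 4 (0.24 log units; within the scatter)), whereas hydrogen in place of trifluoromethyl lies beyond it (a 3.5-fold lower number from compound 2 to compound 3 (0.54 log units; beyond the scatter)), which leaves the methyl compound not clearly separated from either neighbour at this position. With 4-methoxyphenyl held constant, hydroxy in place of hydrogen on an aromatic carbon of the shared core likewise gives no readable difference (a 1.7-fold higher number from compound 1 to compound 4 (0.24 log units; within the scatter)).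

No available evidence bears on what lies behind these numbers. The compounds shown leave open whether a longer chain such as ethyl or propyl on this oxygen, or an amine in place of the hydroxy group of 4-hydroxyphenyl, would move the number beyond the scatter in either direction.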